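The compounds below may be only part of what the source reports. "The series", "measured", "known", "first", "only" and "open" are said of these compounds alone.

Measured compounds in a functional assay on MCF7 cells (Homo sapiens) for antiproliferative activity, read by MTT assay, with a stated time of 3 days; on this read-out lower numbers stand for stronger inhibition and higher numbers for weaker inhibition:
Compound 1 `CCCCC#Cc1cn(C/C=C\CN2C(=O)c3ccccc3C2=O)c(=O)[nH]c1=O` gives 45000 nM.
Compound 2 `O=C1c2ccccc2C(=O)N1C/C=C\Cn1cc(C#CCCc2ccccc2)c(=O)[nH]c1=O` gives only a limit of the assay, > 100000 nM.
Compound 3 `O=C1c2ccccc2C(=O)N1C/C=C/Cn1cc(C#CCCc2ccccc2)c(=O)[nH]c1=O` gives 13000 nM.

Compound 3 has the lowest number of the two real values here. Compound 2 and compound 3 share the same atoms and differ only in configuration: the two compounds have the same atoms and bonds and differ only in configuration as drawn: 1 of 1 stereo elements differ; a double bond is drawn Z in compound 2 and E in compound 3. That difference gives an at least 7.6-fold lower number from compound 2 to compound 3 (0.88 log units; beyond the scatter), which rests on the fact that compounds 2 and 3 differ only in the configuration as drawn and on (the limit of > 100000 nM in this assay, at which 1 of the 3 values shown sits).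

Compound 4 `CCCCC#Cc1cn(C/C=C/CN2C(=O)c3ccccc3C2=O)c(=O)[nH]c1=O` has not yet been measured. It differs from compound 3 by ethyl in place of phenyl on a saturated chain carbon, two bonds along the chain from a triple-bonded carbon. The same change is made from compound 2 to compound 1, (ethyl in place of phenyl on a saturated chain carbon, two bonds along the chain from a triple-bonded carbon), and there it gave an at least 2.2-fold lower number from compound 2 to compound 1 (0.34 log units; beyond the scatter); because of the limit of > 100000 nM in this assay, at which 1 of the 3 values shown sits, only a lower bound of that step is known. For compound 4 the step of a 1.9-fold lower number from compound 3 to compound 4 (0.27 log units; within the scatter) is expected to be of similar size. The expected value of compound 4 is 7000 nM, likely between 2500 nM and 25000 nM.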

Compound 4, half-maximal inhibitory concentration: 8800 nM
Estimate against measurement, compound 4: 1.3-fold (0.10 log units) below, and the stated range covers the measured number.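

In this assay, the change from 4-phenylbut-1-yn-1-yl to hex-1-yn-1-yl gives a 1.5-fold lower number from compound 3 to compound 4 (0.17 log units; within the scatter), so on this core it leaves the number within the scatter. Set beside the same change on the other core, this shows no reversal of direction, but it does not show that the step carries over at the same size: the same change on two cores in this assay, an at least 2.2-fold lower number (0.34 log units; beyond the scatter) from compound 2 to compound 1 and a 1.5-fold lower number (0.17 log units; within the scatter) from compound 3 to compound 4; the limit leaves it open whether they differ The double-bond change gives a 5.1-fold lower number from compound 1 to compound 4 (0.71 log units; beyond the scatter), in the same direction as an at least 7.6-fold lower number from compound 2 to compound 3 (0.88 log units; beyond the scatter), so the E compounds have the lower numbers in both pairs.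

The compounds shown leave open how a longer chain or a terminal amine in place of ethyl or phenyl would behave on either core.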